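Fluoro in Place of Nitro on Compound 3

A few compounds are considered here, and "the series" means these few. Any claim that something is new, unique, unknown or untested is made for them only; others in the source may bear on it.

In a functional assay on MIA PaCa-2 cells (Homo sapiens) for cytotoxicity, read by MTT assay, with a stated time of 4 h (on this read-out higher numbers stand for weaker inhibition and lower numbers for stronger inhibition), compound 3 (`COC1=CC(=O)c2c(COc3ccc([N+](=O)[O-])cc3F)c(C)n(C)c2C1=O`) gives 529 nM, within the scatter of compound 1 (`COC1=CC(=O)c2c(COc3ccc([N+](=O)[O-])cc3)c(C)n(C)c2C1=O`) at 638 nM, while compound 2 (`COC1=CC(=O)c2c(COc3ccccc3)c(C)n(C)c2C1=O`) gives a clearly higher 4560 nM. Compound 4 (`COC1=CC(=O)c2c(COc3ccc(F)cc3F)c(C)n(C)c2C1=O`) differs from compound 3 by fluoro in place of nitro on an aromatic carbon. Within the data shown here, two measured steps bear on this. Losing the nitro group gave a 7.1-fold higher number from compound 1 to compound 2 (0.85 log units; beyond the scatter), whereas adding a fluoro gave only a 1.2-fold lower number from compound 1 to compound 3 (0.08 log units; within the scatter). Among the measured compounds shown here, no measured compound carries fluoro at the place the nitro group leaves, so a rise of similar size is expected, namely a 5.7-fold higher number from compound 3 to compound 4 (0.75 log units; beyond the scatter). Compound 4 is estimated at 3000 nM, within an expected range of 1200 nM to 7500 nM.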

Compound 4, half-maximal inhibitory concentration: 255 nM
Estimate against measurement, compound 4: 12-fold (1.07 log units) above, and the stated range ends above it.
By their numbers in this assay, from the lowest: compound 4; then compounds 3 and 1 (each within the scatter of the next); then compound 2.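

In this assay, the nitro group proves replaceable at this place: putting fluoro there gives a 2.1-fold lower number from compound 3 to compound 4 (0.32 log units; beyond the scatter), so the rise seen on replacing nitro with hydrogen does not extend to this swap. The two fluoro groups together account for an 18-fold lower number from compound 2 to compound 4 (1.25 log units; beyond the scatter), which shows that the phenyl can be much improved without any nitro group. No available evidence explains why fluoro does this here. On these data alone, what remains open is how much each fluoro contributes on its own, and whether an amine or a nitrile at this place would match fluoro.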